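Ethyl for methyl at the ring nitrogen of compound 1

The source may report more compounds than this note shows. Statements on the series, on what has been measured and on what is new or still open speak of the compounds shown alone.

Compound 1 `CCOC(=O)c1ccc(-c2nn(C)c3ccccc23)cc1` carries a methyl on the saturated chain carbon bound to an aromatic nitrogen. In a functional assay on cells (Platelet, Homo sapiens) for inhibition (on this read-out lower numbers stand for stronger inhibition and higher numbers for weaker inhibition), compound 1 gives > 10000 nM, which is a limit of the assay and not a number. Compound 2 `CCOC(=O)c1ccc(-c2nn(Cc3ccc(OC)cc3)c3ccccc23)cc1` gives > 10000 nM in this assay, again a limit rather than a number. Compound 3 `CCOC(=O)c1ccc(-c2nn(Cc3ccccn3)c3ccccc23)cc1` gives > 10000 nM in this assay, also a limit. The steps a step that the two limits leave unreadable from compound 1 to compound 2, a step that the two limits leave unreadable from compound 1 to compound 3 and a step that the two limits leave unreadable from compound 2 to compound 3 are therefore unreadable in size and direction; all that is known is the limit of > 10000 nM in this assay, at which 3 of the 3 values shown sit.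

Compound 4 `CCOC(=O)c1ccc(-c2nn(CC)c3ccccc23)cc1` differs from compound 1 by methyl in place of hydrogen on a saturated chain carbon bound to an aromatic nitrogen. Within the data shown here, no measured step at this place can be read, so nothing points to a gain. Since compound 2 and compound 3 both sit at the limit of > 10000 nM in this assay, at which 3 of the 3 values shown sit, after far larger changes at the same place, compound 4 is expected to remain there as well. The expected step is a step that the limit leaves unreadable from compound 1 to compound 4, meaning no change beyond the scatter. Compound 4 is estimated at 20000 nM, within 8000 nM to 60000 nM, most likely reported only as a limit.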

Compound 4, half-maximal inhibitory concentration: > 10000 nM
Compound 4 was reported as a limit; the forecaster's own chance of this, stated with the estimate: 85%; the middle value is on the limit's open side.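

Compound 4 adds no readable step: its steps with compound 1, compound 2 and compound 3 cannot be read, as all four compounds give only a limit: the limit of > 10000 nM in this assay, at which 4 of the 4 values shown sit.

The compounds shown leave open how strongly any of them inhibits in this assay, and whether any group at this place gives a measurable value.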